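The source may hold more compounds than are shown below. What is called first, only, known or untested is meant among the compounds shown, and "the series" means these compounds.

Measured in a functional assay on BXPC-3 cells (Homo sapiens) for cytotoxicity, read by fluorescence, with a stated time of 48 h; a lower number here means that less compound is needed, a higher number that more compound is needed for the effect:
- compound 1 `CC(C)=CCC/C(C)=C/CC/C(C)=C/CSC[C@H](NC(=O)CCCCCN1CCN(C)CC1)C(=O)N1CCCC1`: 3200 nM
- compound 2 `CC(C)=CCC/C(C)=C/CC/C(C)=C/CSC[C@H](NC(=O)CCCCCN1CCCC1)C(=O)NC1CCCCCC1`: 5800 nM
- compound 3 `CC(C)=CCC/C(C)=C/CC/C(C)=C/CSC[C@H](NC(=O)CCCCCN1CCCC1)C(=O)NC1CCCCCCC1`: 4000 nM

Compound 3, at 4000 nM, sits inside a narrow band, with both compound 1 and compound 2 within the usual scatter of it. The next analogue, compound 4 `CC(C)=CCC/C(C)=C/CC/C(C)=C/CSC[C@H](NC(=O)CCCCCN1CCCC1)C(=O)N1CCCC1`, is still to be measured. It places pyrrolidin-1-yl in place of cyclooctylamino on a carbonyl carbon.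

Among the measured compounds shown here, only one measured step touches this place, the change of ring size on the amide-type nitrogen, a 1.5-fold lower number from compound 2 to compound 3 (0.16 log units; within the scatter). For the measured compounds named here, that step is small, but it keeps the amide hydrogen, which compound 4 loses, so no measured step covers this exact change. Compound 1 also carries pyrrolidin-1-yl on a carbonyl carbon, but it differs from compound 4 elsewhere, and compound 1 gives 3200 nM. A step beyond the scatter in this assay is therefore not expected, and no direction is favoured.

The expected value for compound 4 is 3800 nM, with an estimated range of 1900 nM to 7500 nM. The estimate amounts to a 1.1-fold lower number from compound 3 to compound 4 (0.02 log units; within the scatter).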

Compound 4, half-maximal effective concentration: 6500 nM
Compound 4: middle estimate off by 1.7-fold (0.23 log units), on the low side, and the stated range covers the measured number.
By their numbers in this assay, from the lowest: compounds 1, 3, 2 and 4 (each within the scatter of the next, the first and the last beyond it).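

In this assay, pyrrolidin-1-yl on a carbonyl carbon gives a step within the scatter against both cyclooctylamino (a 1.6-fold higher number from compound 3 to compound 4 (0.21 log units; within the scatter)) and cycloheptylamino (a 1.1-fold higher number from compound 2 to compound 4 (0.05 log units; within the scatter)), so losing the amide hydrogen together with the larger ring does not move the number beyond the scatter in these pairs. Among the compounds shown here, with pyrrolidin-1-yl held on the carbonyl carbon, the change from 4-methylpiperazin-1-yl to pyrrolidin-1-yl on a saturated chain carbon, five bonds along the chain from a carbonyl carbon, gives the only step here beyond the scatter, and a modest one (a 2.0-fold higher number from compound 1 to compound 4 (0.31 log units; beyond the scatter)). No evidence on hand explains these numbers.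

The compounds shown leave ring size and the amide hydrogen tied together, and cyclopentylamino on the carbonyl carbon would separate them. Also open, on these data alone, is how piperidin-1-yl or morpholin-4-yl would compare there.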